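The source may report more compounds than this note shows. Statements on the series, on what has been measured and on what is new or still open speak of the compounds shown alone.

Measured in a functional assay on HEL cells (Homo sapiens), read by microscopy; a lower number here means that less compound is tolerated, a higher number that more compound is tolerated:
- compound 1 `CCCCCCCCC#Cc1cc2cn(COCCO)c(=O)nc2o1`: >= 20000 nM
- compound 2 `CCCCCCCCCc1cc2cn(COCCO)c(=O)nc2o1`: >= 16000 nM
- compound 3 `CCCCCC#Cc1cc2cn(COCCO)c(=O)nc2o1`: >= 100000 nM

Every one of these three values is a limit of this assay, not a number. Compound 3 sits at the limit (the limit of >= 100000 nM in this assay, at which 1 of the 3 values shown sits). Compound 2 sits at the limit (the limit of >= 16000 nM in this assay, at which 1 of the 3 values shown sits). Compound 1 sits at the limit (the limit of >= 20000 nM in this assay, at which 1 of the 3 values shown sits). Compound 3 thus stands only at a limit, and the two further values shown are limits as well, so no ordering among the three can be read.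

Among the compounds with values here, the single step between measured compounds that differ in one place, a step that the two limits leave unreadable from compound 1 to compound 3, is left unreadable by the two limits. Compound 1 and compound 2 differ by a triple bond on the chain; both values are limits, so that pair shows no readable step either.

Compound 4 `CCCCCc1cc2cn(COCCO)c(=O)nc2o1` differs from compound 3 by pentyl in place of hept-1-yn-1-yl on an aromatic carbon. Within the data shown here, no measured step bears on this change with a readable size, so in this assay no step beyond the scatter can be predicted in either direction, and a further limit is the likeliest outcome. For compound 4 the expected value is 60000 nM, with a range from 16000 nM to 100000 nM. The expected step is an at least 1.6-fold lower number from compound 3 to compound 4 (0.22 log units; that floor lies within the scatter).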

Compound 4, minimum cytotoxic concentration: > 400000 nM
Compound 4: no number, only a limit; the forecaster's own chance of this, stated with the estimate: 85%; at least 6.6-fold (0.82 log units) between middle value and limit.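

In this assay compound 4 gives > 400000 nM, which is a limit and not a number. Within the data shown here, compound 2 and compound 3 also stand only at limits, so no step to compound 4 can be read. The compounds shown leave open whether chain length or the triple bond changes the tolerated concentration at all.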